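The compounds below may be only part of what the source reports. "The series", "measured", "known", "first", "only" and "open" are said of these compounds alone.

Measured compounds in an ADME assay on MDCK cells (Canis lupus familiaris) for cytotoxicity; on this read-out higher numbers stand for lower toxicity in this test and lower numbers for higher toxicity in this test:
compound 1, `Cn1ccnc1Sc1cnc(-c2ccc(Cl)cc2)nc1-c1ccccc1O`, gives 80100 ug/mL.
compound 2, `Cn1ccnc1Sc1cnc(-c2ccc(N)cc2)nc1-c1ccccc1O`, gives 80100 ug/mL.

Compound 2 stands level with compound 1 on the numbers shown; the step of no change at the digits printed from compound 1 to compound 2 (within the scatter) is within the scatter, so the two compounds cannot be told apart in this assay. The change from compound 2 to compound 3, `Cn1ccnc1Sc1cnc(-c2ccccc2)nc1-c1ccccc1O`, is hydrogen in place of amino on an aromatic carbon. Cut one bond further out, the same difference reads 4-aminophenyl to phenyl.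

Among the compounds with values here, only one measured step bears on this position: no change at the digits printed from compound 1 to compound 2 (within the scatter), where an amino group replaced a chloro on the same aromatic carbon without a shift beyond the scatter. Within the data shown here, removing the amino group altogether, leaving hydrogen, is a different exchange at the same place, but the single comparison available gives no sign that this carbon influences the read-out. The expectation for compound 3 is therefore a step of no change at the digits printed from compound 2 to compound 3 (within the scatter), that is, none beyond the scatter. Compound 3 is estimated at 80100 ug/mL, with a range from 40000 ug/mL to 160000 ug/mL.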

Compound 3, half-maximal cytotoxic concentration: 120000 ug/mL
Compound 3: the middle estimate sits 1.5-fold (0.18 log units) below what was measured; low and high end bracket the measured number.
By their numbers in this assay, from the lowest: compounds 1, 2 and 3 (each within the scatter of the next).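

In this assay, hydrogen in place of amino gives a 1.5-fold higher number from compound 2 to compound 3 (0.18 log units; within the scatter), and hydrogen in place of chloro gives a 1.5-fold higher number from compound 1 to compound 3 (0.18 log units; within the scatter). The earlier pair only exchanged one substituent for another on this aromatic carbon; these steps add the case with no substituent there, the change from 4-aminophenyl to phenyl, and hydrogen, amino and chloro cannot be told apart on this read-out. No supporting data bear on why this position shows no step beyond the scatter.

Going by these compounds, these three compounds span only a narrow set of small substituents, so it remains open whether a carboxylic acid, a longer chain such as a butoxy group, or a second ring on this same aromatic carbon would move the read-out beyond the scatter. On these data alone, it also remains open whether the same flat result would hold for these exchanges with a different group elsewhere on the shared core, such as an ether in place of the hydroxyl group.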